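A few compounds are considered here, and "the series" means these few. Any claim that something is new, unique, unknown or untested is made for them only; others in the source may bear on it.

Measured so far in a functional assay on HCC827 cells (Homo sapiens) for inhibition, read by MTT assay, with a stated time of 48 h, tested at 10 uM; a higher number here means more inhibition at the concentration tested (going by the name of the read-out), a lower number less inhibition:
Compound 1 `COc1cc(NC(=O)Nc2cc(Nc3cc(C)cc(F)c3)ncn2)cc(OC)c1` gives 62.1%.
Compound 2 `COc1cc(NC(=O)Nc2cc(Nc3ccc(OC)c(I)c3)ncn2)cc(OC)c1` gives 61.7%.
Compound 3 `COc1cc(NC(=O)Nc2cc(Nc3ccc(F)c(Cl)c3)ncn2)cc(OC)c1` gives 53.1%.

Compound 3 holds the lowest of these three numbers, yet both neighbours sit close: the step of a number 9 percentage points lower from compound 1 to compound 3 (within the scatter) and the step of a number 8.6 percentage points lower from compound 2 to compound 3 (within the scatter) each stay within the scatter, so the three compounds cannot be ranked. Compound 4 `COc1cc(NC(=O)Nc2cc(Nc3ccc(C(C)(C)C)cc3)ncn2)cc(OC)c1` is not yet measured in this assay. It differs from compound 3 in one place: 4-(tert-butyl)phenyl in place of 3-chloro-4-fluorophenyl on a nitrogen on an aromatic ring. Within the data shown here, every measured step so far exchanged one phenyl group for another on that nitrogen, and none of them, including a number 0.4 percentage points lower from compound 1 to compound 2 (within the scatter), moved the number beyond the scatter. Among the measured compounds shown here, no measured step involves a 4-(tert-butyl)phenyl group, so the expectation rests on that pattern alone. The step to compound 4 is therefore expected to be a number 1.9 percentage points higher from compound 3 to compound 4 (within the scatter), with no change beyond the scatter. Compound 4 is estimated at 55%, in the range 35% to 72%.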

Compound 4, a percentage reported as inhibition, at one concentration (the size of the read-out at that concentration, not a potency): 32.7%
The estimate for compound 4 lay 22.3 percentage points above the measured number, and the stated range ends above it.
By their numbers in this assay, from the lowest: compound 4; then compounds 3, 2 and 1 (each within the scatter of the next).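

In this assay, the group on this nitrogen does matter: a number 20.4 percentage points lower from compound 3 to compound 4 (beyond the scatter), a number 29 percentage points lower from compound 2 to compound 4 (beyond the scatter) and a number 29.4 percentage points lower from compound 1 to compound 4 (beyond the scatter). Among the groups shown, only 4-(tert-butyl)phenyl separates from the others, while the 3-chloro-4-fluorophenyl, 3-iodo-4-methoxyphenyl and 3-fluoro-5-methylphenyl groups stay within the scatter of one another. Nothing available explains this drop.

As far as these compounds go, it remains open whether the drop belongs to the tert-butyl group itself or to the loss of the other substituents. A plain phenyl or a 4-methylphenyl group on that nitrogen would bear on this question.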